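Swapping an Aromatic Ring on the Amide of Compound 2

The compounds below may be only part of what the source reports. "The series", "measured", "known", "first", "only" and "open" are said of these compounds alone.

Measured so far:
compound 1 `CN1CCC(C(=O)N2Cc3c(NC(=O)NCc4ccccc4)n[nH]c3C2(C)C)CC1`: > 225000 nM
compound 2 `CN1CCC(C(=O)N2Cc3c(NC(=O)c4ccc(C(F)(F)F)cc4)n[nH]c3C2(C)C)CC1`: 191000 nM

Both compounds share one core and differ only in the group on the carbonyl carbon. In a physicochemical assay for solubility, at pH 7 (on this read-out higher numbers stand for higher solubility and lower numbers for lower solubility), compound 1 reaches only a limit, > 225000 nM, not a number; (the limit of > 225000 nM in this assay, at which 1 of the 2 values shown sits). Compound 2 gives 191000 nM in this assay, the only plain number shown. Among the measured compounds shown here, the one measured step, an at least 1.1-fold lower number from compound 1 to compound 2 (0.07 log units; that floor lies within the scatter), lies within the scatter.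

Compound 3 `CN1CCC(C(=O)N2Cc3c(NC(=O)c4ccncc4)n[nH]c3C2(C)C)CC1` is not yet measured. It differs from compound 2 by pyridin-4-yl in place of 4-(trifluoromethyl)phenyl on a carbonyl carbon. No measured step touches this kind of change; the only step shown concerns a different group and was within the scatter. For compound 3 the step of a 1.2-fold higher number from compound 2 to compound 3 (0.08 log units; within the scatter) is therefore expected to be small, and it may well again be reported as a limit. Compound 3 is estimated at 230000 nM in this assay, between 130000 nM and 350000 nM.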

Compound 3, solubility: > 225000 nM
Compound 3 gave a limit, no number (the forecaster's own chance of this, stated with the estimate: 55%); the middle value lies beyond the limit too.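

In this assay, the place on the carbonyl carbon now holds pyridin-4-yl, a ring with a hetero atom, instead of the all-carbon ring of 4-(trifluoromethyl)phenyl, and the measured step is an at least 1.1-fold higher number from compound 2 to compound 3 (0.07 log units; that floor lies within the scatter). Compound 3 gives a limit rather than a number, so only this floor is known and the true size of the step stays hidden. The step between compound 1 and compound 3 cannot be read, and most of the compounds shown now sit at one limit: the limit of > 225000 nM in this assay, at which 2 of the 3 values shown sit.

As far as these compounds go, it remains open whether an amine or a carboxylic acid in this place on the carbonyl carbon would give a plain number in this assay. The compounds shown also leave open how this ring swap would read in any other kind of assay.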